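Shrinking the ring amine: compound 3 to compound 4

The source may hold more compounds than are shown below. What is called first, only, known or untested is meant among the compounds shown, and "the series" means these compounds.

Compound 3 `NC1CCN(c2ccc3cc(NC(=O)CCc4ccc(C(F)(F)F)cc4)ccc3n2)C1` gives 12 nM in an assay on isolated protein for displacement of a labelled ligand from melanin-concentrating hormone receptor 1 (Homo sapiens) (on this read-out lower numbers stand for stronger inhibition and higher numbers for weaker inhibition), the second highest of three numbers: compound 1 `CC(C)N(C)c1ccc2cc(NC(=O)CCc3ccc(C(F)(F)F)cc3)ccc2n1` gives 2 nM and compound 2 `CCCN(CCC)c1ccc2cc(NC(=O)CCc3ccc(C(F)(F)F)cc3)ccc2n1` gives 490 nM. Compound 4 `CCN(CC)c1ccc2cc(NC(=O)CCc3ccc(C(F)(F)F)cc3)ccc2n1` carries diethylamino in place of 3-aminopyrrolidin-1-yl on an aromatic carbon. The closest guide is a 250-fold higher number from compound 1 to compound 2 (2.39 log units; beyond the scatter), where longer propyl chains on the amine went with a much weaker result, while a 6.0-fold higher number from compound 1 to compound 3 (0.78 log units; beyond the scatter) and a 41-fold lower number from compound 2 to compound 3 (1.61 log units; beyond the scatter) place the ring amine between those two. Diethylamino is an open-chain amine shorter than the dipropylamino of compound 2 and close in shape to the isopropyl(methyl)amino of compound 1, so the result should sit nearer compound 1. Compound 4 is therefore expected to show a 1.2-fold lower number from compound 3 to compound 4 (0.08 log units; within the scatter). The estimate for compound 4 is 10 nM, within a range from 2 nM to 60 nM.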

Compound 4, half-maximal inhibitory concentration: 88 nM
The estimate for compound 4 lay 8.8-fold (0.94 log units) below the measured number, outside the stated range (above it).
By their numbers in this assay, from the lowest: compound 1; then compound 3; then compound 4; then compound 2.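

In this assay, swapping dipropylamino for diethylamino recovers only part of the lost strength, a 5.6-fold lower number from compound 2 to compound 4 (0.75 log units; beyond the scatter), so small changes among open-chain amines at this position matter greatly: diethylamino falls well short of isopropyl(methyl)amino, a 44-fold higher number from compound 1 to compound 4 (1.64 log units; beyond the scatter). It also falls short of the ring amine, a 7.3-fold higher number from compound 3 to compound 4 (0.87 log units; beyond the scatter), so compound 3 outranks both the diethylamino and dipropylamino compounds, while compound 1 goes against any simple preference for the ring. Nothing available explains these differences.

Still open, on these data alone, is whether the ring or its amino group drives the result for compound 3, and how a plain pyrrolidin-1-yl or a dimethylamino group would compare.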